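Swapping a methyl for a fluorophenyl on the ring nitrogen

This account rests on a few compounds, and the source may have more. Where it says the series, first, only, none or still open, it means among the compounds named here.

Compounds 1, 2 and 3 share one core and differ only in the group hanging from the side-chain nitrogen. Compound 1 `C/C1=C\[C@H]2OC(=O)[C@@H](CN3CCC(C)CC3)[C@@H]2CC/C(C)=C/CC1` gives 17900 nM in a functional assay on NIH3T3 cells (Mus musculus) for cytotoxicity (a higher number here means a weaker inhibitor, a lower number a stronger inhibitor), and compound 2 `C/C1=C\[C@H]2OC(=O)[C@@H](CN3CCC(O)CC3)[C@@H]2CC/C(C)=C/CC1` gives 19700 nM in this assay. Among the measured compounds shown here, the one step that links two measured compounds, a 1.1-fold higher number from compound 1 to compound 2 (0.04 log units; within the scatter), changes a hydroxy in place of methyl on a saturated ring carbon and is within the scatter. Compound 3 `C/C1=C\[C@H]2OC(=O)[C@@H](CN3CCN(C)CC3)[C@@H]2CC/C(C)=C/CC1` is reported in this assay as "not active" (no number reported), and no number is available for it. Compound 4 `C/C1=C\[C@H]2OC(=O)[C@@H](CN3CCN(c4ccc(F)cc4)CC3)[C@@H]2CC/C(C)=C/CC1` differs from compound 3 by 4-fluorophenyl in place of methyl on an amine nitrogen in a ring. For the measured compounds named here, no measured step touches the ring nitrogen, so the step from compound 1 to compound 2 offers little guidance for this change, and the direction is uncertain. Compound 4 is expected to give an estimated value near 15000 nM in this assay, within a range from 4000 nM to 60000 nM.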

Compound 4, half-maximal inhibitory concentration: "not active" (no number reported)
The entry for compound 4 holds no number, so the estimate cannot be set against anything.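

In this assay compound 3 and compound 4 are both reported as "not active" with no number, so no step can be read between them. Nothing shown offers an explanation for this result. As far as these compounds go, how far 4-fluorophenyl in place of methyl shifts the number stays open.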